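Pyridin-2-yl in place of isopropyl on a carbonyl carbon

The source may report more compounds than this note shows. Statements on the series, on what has been measured and on what is new or still open speak of the compounds shown alone.

Measured so far in a physicochemical assay for lipophilicity, read by HPLC, measured as chromatographic lipophilicity, at pH 7.4 (a lower number here means a more polar compound, a higher number a more lipophilic compound), for this series:
- compound 1 `CC(C)C(=O)N1N=CCC1c1ccccc1` gives 4.4
- compound 2 `CC(C)(C)C(=O)N1N=CCC1C1CCOCC1` gives 4.1

In this assay compound 1 stands at 4.4 and sits within the scatter of compound 2 at 4.1 so no order can be read from this pair. Among the compounds with values here, the two compounds differ in more than one place, and they offer no single-change step.

Compound 3 `O=C(c1ccccn1)N1N=CCC1c1ccccc1` has not yet been measured. It keeps the core of compound 1 and carries one change, pyridin-2-yl in place of isopropyl on a carbonyl carbon. Within the data shown here, no measured compound carries pyridin-2-yl, so the data give no direct guide to the size of this step. A moderate downward step is expected, estimated as a number 0.50 log units lower from compound 1 to compound 3 (beyond the scatter) and so only a little beyond the scatter. This expectation rests on the structural change alone and is held loosely, with no change at all still inside the range. Compound 3 is estimated at 3.9 (range 3.4 to 4.4) in this assay for now.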

Compound 3, distribution coefficient: 2.4
Compound 3: middle estimate off by 1.50 log units, on the high side; the measured number lies below the stated range.
By their numbers in this assay, from the lowest: compound 3; then compounds 2 and 1 (each within the scatter of the next).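

In this assay, the group on a carbonyl carbon whose other neighbour is an amide-type nitrogen in a ring proves to be a sensitive point in the series: pyridin-2-yl in place of isopropyl sets the reading a number 2.00 log units lower from compound 1 to compound 3 (beyond the scatter). Within the data shown here, this is the first single-change step available, as the earlier pair differed in more than one place and could not isolate any one position. The reading falls even though the entering group is the larger by count, with 6 heavy atoms against 3, one six-membered aromatic ring with 1 hetero atom and 1 hydrogen-bond acceptor, and no measurement at hand accounts for the size of this step.

As far as these compounds go, it remains open how much of the step belongs to the ring nitrogen and how much to the aromatic ring as such: phenyl on the same carbonyl carbon would separate the two, and pyridin-3-yl or pyridin-4-yl would test the place of that nitrogen. Also open, from the compounds shown here alone, is whether pyridin-2-yl gives a step of similar size on the core of compound 2 .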